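Shortening the alkyl chain on the urea nitrogen

A few compounds are considered here, and "the series" means these few. Any claim that something is new, unique, unknown or untested is made for them only; others in the source may bear on it.

Compound 1 `N#CC1CN1C(=O)Nc1ccc(Cl)c(Cl)c1` and compound 2 `CCCCNC(=O)N1CC1C#N` share the same core and differ in what sits on the urea nitrogen. In a functional assay on MCF7 cells (Homo sapiens) for inhibition (on this read-out lower numbers stand for stronger inhibition and higher numbers for weaker inhibition), compound 1 gives 4400 nM. In this assay compound 2 reaches only a limit of the assay, > 12000 nM, and not a number. Compound 2 therefore stands at the weak end of the two values shown, at the limit of > 12000 nM in this assay, at which 1 of the 2 values shown sits. Compound 3 `CNC(=O)N1CC1C#N` is the next entry of the series: hydrogen in place of propyl on a saturated chain carbon bound to an amide-type nitrogen. Among the compounds with values here, no step between measured compounds is available to size this change. Because compound 2 sits at the limit of > 12000 nM in this assay, at which 1 of the 2 values shown sits, a shortened alkyl is not expected to carry compound 3 into the measurable range. For compound 3 the expected step is none beyond the scatter, meaning a step that the limit leaves unreadable from compound 2 to compound 3. Compound 3 is estimated at 15000 nM, within 5000 nM to 40000 nM, with a limit again the likeliest outcome.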

Compound 3, half-maximal inhibitory concentration: 18000 nM
Compound 3: middle estimate off by 1.2-fold (0.08 log units), on the low side; the measured number falls inside the stated range.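

No step can be read from compound 2 to compound 3. For compound 2, the value [ > 12000 nM ] is a limit and not a number. The compounds shown leave open how far the change from butyl to methyl alone shifts inhibition.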